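The source may report more compounds than this note shows. Statements on the series, on what has been measured and on what is new or still open speak of the compounds shown alone.

Measured so far in an assay on CHO cells for displacement of a labelled ligand from Substance-P receptor (Homo sapiens); on this read-out lower numbers stand for stronger inhibition and higher numbers for weaker inhibition:
compound 1 `C[C@@H](O[C@H]1CN2C(=O)C=C(c3ccc(C#N)cc3)CC2[C@@H]1c1ccc(F)cc1)c1cc(C(F)(F)F)cc(C(F)(F)F)c1`: 1.8 nM
compound 2 `C[C@@H](O[C@H]1CN2C(=O)C=C(c3cc[n+]([O-])cc3)CC2[C@@H]1c1ccc(F)cc1)c1cc(C(F)(F)F)cc(C(F)(F)F)c1`: 0.1 nM
compound 3 `COc1cc(C2=CC(=O)N3C[C@H](O[C@H](C)c4cc(C(F)(F)F)cc(C(F)(F)F)c4)[C@@H](c4ccc(F)cc4)C3C2)ccn1`: 1.1 nM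

Compound 3 stands second highest of the three: one step is a 1.6-fold lower number from compound 1 to compound 3 (0.21 log units; within the scatter), the other is an 11-fold higher number from compound 2 to compound 3 (1.04 log units; beyond the scatter). Compound 4 `C[C@@H](O[C@H]1CN2C(=O)C=C(c3cnn(Cc4ccccc4)c3)CC2[C@@H]1c1ccc(F)cc1)c1cc(C(F)(F)F)cc(C(F)(F)F)c1` differs from compound 3 in one place: 1-benzyl-1H-pyrazol-4-yl in place of 2-methoxypyridin-4-yl on a double-bonded ring carbon. All measured steps concern this same double-bonded ring carbon: an 18-fold lower number from compound 1 to compound 2 (1.26 log units; beyond the scatter), a 1.6-fold lower number from compound 1 to compound 3 (0.21 log units; within the scatter), an 11-fold higher number from compound 2 to compound 3 (1.04 log units; beyond the scatter). Swaps of the aryl group here thus range from within the scatter to large, and none involves a five-membered ring or a benzyl group, so the direction is uncertain. A moderately higher number is expected, a 2.7-fold higher number from compound 3 to compound 4 (0.44 log units; beyond the scatter). Compound 4 is estimated at 3 nM, within 0.8 nM to 12 nM.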

Compound 4, half-maximal inhibitory concentration: 1.9 nM
The estimate for compound 4 lay 1.6-fold (0.20 log units) above the measured number; the measured number falls inside the stated range.
By their numbers in this assay, from the lowest: compound 2; then compounds 3, 1 and 4 (each within the scatter of the next).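

Going by these compounds alone, on this double-bonded ring carbon, 1-benzyl-1H-pyrazol-4-yl, the only group here with a five-membered aromatic ring and the largest by heavy atoms, leaves the number unmoved in this assay: a 1.7-fold higher number from compound 3 to compound 4 (0.24 log units; within the scatter) and a 1.1-fold higher number from compound 1 to compound 4 (0.02 log units; within the scatter) both lie within the scatter. Compound 2 stays apart, with a 19-fold higher number from compound 2 to compound 4 (1.28 log units; beyond the scatter), so added heavy atoms alone do not separate compound 1, compound 3 and compound 4. Nothing available accounts for this result.

As far as these compounds go, whether the benzyl ring matters remains open, as 1-methyl-1H-pyrazol-4-yl would test. A carboxylic acid or an amine on this carbon is also untested against compound 2 in these data.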